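6-Methylpyridin-3-yl in place of 3-fluorophenyl

This account rests on a few compounds, and the source may have more. Where it says the series, first, only, none or still open, it means among the compounds named here.

Compound 1 `Nc1ccccc1NC(=O)c1ccc(NC(=S)NCc2cccc(F)c2)cc1`: 5900 nM
Compound 2 `Nc1ccccc1NC(=O)c1ccc(NC(=O)NCc2ccc(F)nc2)cc1`: 14000 nM

Both compounds were tested in a functional assay on HCT-116 cells (Homo sapiens) for cytotoxicity, read by MTT assay, with a stated time of 72 h; on this read-out lower numbers stand for stronger inhibition and higher numbers for weaker inhibition. Compound 1, at 5900 nM, has the lower of the two numbers and is therefore the stronger inhibitor. Compound 2 gives 14000 nM, a gap beyond the usual scatter.

The next compound to be tested is compound 3 `Cc1ccc(CNC(=S)Nc2ccc(C(=O)Nc3ccccc3N)cc2)cn1`. It keeps the core of compound 1 and carries 6-methylpyridin-3-yl in place of 3-fluorophenyl on a saturated chain carbon bound to an amide-type nitrogen.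

Among the compounds with values here, no measured pair isolates this change. Compound 2, at 14000 nM, also carries a six-membered aromatic ring with a hetero atom, which hints at weaker inhibition. It differs from compound 1 in more than one place, however, so the hint is faint. In this assay, a slight shift toward weaker inhibition is expected, probably not beyond the scatter, and the estimated step is a 1.3-fold higher number from compound 1 to compound 3 (0.10 log units; within the scatter). Compound 3 is expected to give 7500 nM, with an estimated range of 2800 nM to 20000 nM.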

Compound 3, half-maximal inhibitory concentration: 11000 nM
Compound 3: the middle estimate sits 1.5-fold (0.17 log units) below what was measured; measured number inside the range.
By their numbers in this assay, from the lowest: compounds 1, 3 and 2 (each within the scatter of the next, the first and the last beyond it).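

Within the data shown here, the pair of compound 1 and compound 3 is the first to isolate this change: in this assay, 6-methylpyridin-3-yl in place of 3-fluorophenyl on a saturated chain carbon bound to an amide-type nitrogen gives a 1.9-fold higher number from compound 1 to compound 3 (0.27 log units; within the scatter) and the core of compound 1 stays the same. At this position, then, a six-membered aromatic ring with one hetero atom and one hydrogen-bond acceptor can take the place of a carbon-only ring with no hydrogen-bond acceptor, and the step does not go beyond the scatter. No measurement shown here offers an explanation for this result.

The ring nitrogen, the methyl group and the loss of the fluorine all come in a single step, and these compounds do not separate their contributions. Going by these compounds, it also remains open whether a different group on this ring, such as a carboxylic acid or a dimethylamino group, would give a step beyond the scatter in this assay on the same core.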